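A few compounds are considered here, and "the series" means these few. Any claim that something is new, unique, unknown or untested is made for them only; others in the source may bear on it.

Compound 3 `O=C(COc1cccc2ccccc12)N/N=C/c1ccccc1` holds the highest of the three numbers measured in a physicochemical assay for lipophilicity, measured as octanol-water partition (on this read-out higher numbers stand for higher lipophilicity and lower numbers for lower lipophilicity), giving 4.02. Its nearest neighbour is compound 2 `O=C(COc1cccc2ccccc12)N/N=C/c1cccc([N+](=O)[O-])c1`, which gives 3.97, and the furthest is compound 1 `O=C(COc1cccc2ccccc12)N/N=C/c1cccc(O)c1`, which gives 3.73; both gaps lie within the scatter, so no order among the three can be read from them. The step to compound 4 `O=C(COc1cccc2ccccc12)N/N=C/c1ccccc1[N+](=O)[O-]` is nitro in place of hydrogen on an aromatic carbon, placed ortho to a large group. The measured step that bears most directly on it is a number 0.05 log units higher from compound 2 to compound 3 (within the scatter), the same exchange of nitro and hydrogen on an aromatic carbon, seen in the opposite direction and at another site on the ring. The steps of a number 0.24 log units higher from compound 1 to compound 2 (within the scatter) and a number 0.29 log units higher from compound 1 to compound 3 (within the scatter) touch the nitro group only through the hydroxy compound and add nothing beyond the scatter either. Because the exchange in a number 0.05 log units higher from compound 2 to compound 3 (within the scatter) left this assay essentially unchanged, the move to compound 4 is expected to bring no step beyond the scatter in either direction. Compound 4 is therefore estimated at 3.95 in this assay, with a range from 3.6 to 4.3. That estimate corresponds to an expected step of a number 0.07 log units lower from compound 3 to compound 4 (within the scatter), which is within the scatter.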

Compound 4, partition coefficient: 3.97
For compound 4 the middle estimate is 0.02 log units below the measured one, within the range that was stated.
By their numbers in this assay, from the lowest: compounds 1, 2, 4 and 3 (each within the scatter of the next).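

Placed ortho to a large group, nitro in place of hydrogen on an aromatic carbon gives a number 0.05 log units lower from compound 3 to compound 4 (within the scatter) in this assay, so this position too shows no step beyond the scatter for this exchange. Until now the nitro group had been seen only at another site on the ring, where compound 2 gives 3.97 on this read-out, while compound 4 gives the same printed number, 3.97 here, and the two sites cannot be told apart by these values. No measurement is at hand that would explain this result.

The compounds shown carry only hydrogen, hydroxy or nitro on this ring, and all their values in this assay lie within the scatter of one another, so they set no limit on how far a substituent on this ring can shift the read-out. From the compounds shown here alone, whether an amine, a carboxylic acid or a longer chain placed ortho to a large group would bring a step beyond the scatter remains open, as does what hydroxy would give at that place.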